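A few compounds are considered here, and "the series" means these few. Any claim that something is new, unique, unknown or untested is made for them only; others in the source may bear on it.

In an ADME assay on PBMC cells (Homo sapiens) for cytotoxicity (a lower number here means that less compound is tolerated, a higher number that more compound is tolerated), compound 1 `CC(CCNC(=O)c1c(Cl)cncc1Cl)N1CCC(C(Oc2cccc(Cl)n2)c2ccc(OC(F)(F)F)cc2)CC1` gives 6000 nM and compound 2 `CC(CCNC(=O)c1c(Cl)cncc1Cl)N1CCC(C(Oc2cccc(C(=O)O)n2)c2ccc(C(F)(F)F)cc2)CC1` gives 28700 nM; of these two numbers, compound 2 has the higher and compound 1 the lower, a gap beyond the scatter. Compound 3 `CCO/N=C(/c1ccc(Br)cc1)C1CCN(C(CC)CCNC(=O)c2c(C)cc[n+]([O-])c2C)CC1` is reported in this assay only as a limit, > 177000 nM, at which (the limit of > 177000 nM in this assay, at which 1 of the 3 values shown sits). Compound 4 `COC(=O)c1cccc(OC(c2ccc(C(F)(F)F)cc2)C2CCN(C(C)CCNC(=O)c3c(Cl)cncc3Cl)CC2)c1` is not yet measured; it differs from compound 2 in one place: 3-(methoxycarbonyl)phenyl in place of 6-carboxypyridin-2-yl on an oxygen on a saturated carbon. Within the data shown here, no pair of measured compounds shows the effect of such a change, so the step from compound 2 to compound 4 can only be guessed; the author expects compound 4 to sit below compound 2, with the expected step being a 2.4-fold lower number from compound 2 to compound 4 (0.38 log units; beyond the scatter). The estimate for compound 4 is 12000 nM, between 4000 nM and 40000 nM.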

Compound 4, half-maximal cytotoxic concentration: 15200 nM
For compound 4 the middle estimate is 1.3-fold (0.10 log units) below the measured one, within the range that was stated.
By their numbers in this assay, from the lowest: compound 1; then compounds 4 and 2 (each within the scatter of the next). At a limit, above all of these: compound 3.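

In this assay, among these compounds, this is the first step that can be read at this place, on an oxygen on a saturated carbon: a 1.9-fold lower number from compound 2 to compound 4 (0.28 log units; within the scatter). Replacing 6-carboxypyridin-2-yl with 3-(methoxycarbonyl)phenyl therefore gives no change that can be told from the scatter, even though the hydrogen-bond donor is lost and the ring nitrogen goes. Nothing measured here bears on a cause for this step. The ring and its substituent change together in this step. From the compounds shown here alone, what a carboxylic acid on the carbon-only ring, or a methyl ester or an amine on the six-membered ring with its nitrogen, would give remains open.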